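A few compounds are considered here, and "the series" means these few. Any claim that something is new, unique, unknown or untested is made for them only; others in the source may bear on it.

Compound 1 `Cc1nc2c(c(N(C)c3ccc(OCCCC(=O)NO)cc3)n1)CCC2` and compound 2 `Cc1nc2c(c(N(C)c3ccc(OCCCCCC(=O)NO)cc3)n1)CCC2` share a core and differ by one chain. In an assay on isolated protein for inhibition of histone deacetylase 8 (Homo sapiens), read by fluorescence, with a stated time of 1 h (a higher number here means a weaker inhibitor, a lower number a stronger inhibitor), compound 1 gives 6190 nM, and compound 2 gives 1000 nM. That change, (2-(hydroxycarbamoyl)ethyl in place of hydroxycarbamoyl on a saturated chain carbon, three bonds along the chain from an oxygen on an aromatic ring), brought a 6.2-fold lower number from compound 1 to compound 2 (0.79 log units; beyond the scatter). Compound 3 `Cc1nc(N(C)c2cccc(OCC(=O)NO)c2)c2ccccc2n1` has a different core; the difference between the two cores is not broken down here. In this assay compound 3 reaches only the limit > 1000 nM, which is a limit and not a number. Compound 4 `Cc1nc(N(C)c2cccc(OCCCC(=O)NO)c2)c2ccccc2n1` carries the same kind of change, (2-(hydroxycarbamoyl)ethyl in place of hydroxycarbamoyl on a saturated chain carbon bound to an oxygen on an aromatic ring), though here the place is a saturated chain carbon bound to an oxygen on an aromatic ring rather than three bonds along the chain. Compound 4 is expected to show a step that the limit leaves unreadable from compound 3 to compound 4, resting on the step from compound 1 to compound 2 a 6.2-fold lower number from compound 1 to compound 2 (0.79 log units; beyond the scatter). Compound 4 is estimated at 3000 nM, between 800 nM and 15000 nM.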

Compound 4, half-maximal inhibitory concentration: > 1000 nM
Compound 4 ended at the assay's limit; the forecaster's own chance of this, stated with the estimate: 40%; the middle value is on the limit's open side.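

Compound 3 and compound 4 both end at a limit, not a number, in this assay, so no step between them can be read: the limit of > 1000 nM in this assay, at which 2 of the 4 values shown sit.

As far as these compounds go, whether 2-(hydroxycarbamoyl)ethyl in place of hydroxycarbamoyl lowers the number on the core of compound 3, as it does on the core of compound 1, stays open.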